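The source may hold more compounds than are shown below. What is called first, only, known or untested is meant among the compounds shown, and "the series" means these compounds.

In a functional assay on RAW264.7 cells (Mus musculus) for inhibition, with a stated time of 4 days (on this read-out higher numbers stand for weaker inhibition and lower numbers for stronger inhibition), three compounds built on one shared core have been measured. Compound 1 `COc1cc(/C=C/C(=O)c2cccc(-n3cc(-c4ccc(F)cc4)nn3)c2)ccc1O` gives 6450 nM. Compound 2 `COc1cc(/C=C/C(=O)c2cccc(-n3cc(-c4ccc(C)cc4)nn3)c2)ccc1O` gives 15400 nM, and compound 3 `COc1cc(/C=C/C(=O)c2cccc(-n3cc(-c4cccc(Cl)c4)nn3)c2)ccc1O` gives 14300 nM. Compound 2 stands highest of the three numbers, yet compound 3 lies so close that the two cannot be ranked, since a 1.1-fold lower number from compound 2 to compound 3 (0.03 log units; within the scatter). Against compound 1 the gap is real: a 2.4-fold higher number from compound 1 to compound 2 (0.38 log units; beyond the scatter), and in the same direction a 2.2-fold higher number from compound 1 to compound 3 (0.35 log units; beyond the scatter).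

Compound 4 `COc1ccc(/C=C/C(=O)c2cccc(-n3cc(-c4ccc(C)cc4)nn3)c2)cc1O` has not yet been measured. It differs from compound 2 in one place, (3-hydroxy-4-methoxyphenyl in place of 4-hydroxy-3-methoxyphenyl on a double-bonded chain carbon bound to a double-bonded chain carbon); the leaving and entering groups have the same atoms and the same counts of donors and acceptors, only joined differently. Within the data shown here, all three measured steps alter the aromatic ring carrying fluoro, methyl or chloro, and none of them touches the 4-hydroxy-3-methoxyphenyl, so no measured step bears on this change. Those steps were modest at most, and nothing here gives the change a direction. The expected step is a 1.0-fold lower number from compound 2 to compound 4 (0.01 log units; within the scatter), essentially nothing beyond the scatter. Compound 4 is therefore estimated at 15000 nM, within a range from 5000 nM to 45000 nM.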

Compound 4, half-maximal inhibitory concentration: 1700 nM
Compound 4: middle estimate off by 8.8-fold (0.95 log units), on the high side, and the stated range ends above it.
By their numbers in this assay, from the lowest: compound 4; then compound 1; then compounds 3 and 2 (each within the scatter of the next).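

Moving from 4-hydroxy-3-methoxyphenyl to 3-hydroxy-4-methoxyphenyl on a double-bonded chain carbon bound to a double-bonded chain carbon gives a 9.1-fold lower number from compound 2 to compound 4 (0.96 log units; beyond the scatter) in this assay and shows that this part of the molecule matters strongly for the read-out. This step is larger than a 2.4-fold higher number from compound 1 to compound 2 (0.38 log units; beyond the scatter) and a 2.2-fold higher number from compound 1 to compound 3 (0.35 log units; beyond the scatter), the steps seen when only the ring carrying fluoro, methyl or chloro was altered. The two groups hold the same atoms and the same counts of donors and acceptors, and they differ only in how those atoms are joined. No measurement shown explains why this arrangement gives the lower number.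

Among these compounds, the swap is seen only in the compounds carrying the 4-methylphenyl group, so it remains open whether it would give a step of similar size with the 4-fluorophenyl of compound 1 or the 3-chlorophenyl of compound 3. On these data alone, it is also open how the number would respond to an amine in place of the hydroxy group, or to an ethoxy group in place of the methoxy group.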